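This account rests on a few compounds, and the source may have more. Where it says the series, first, only, none or still open, it means among the compounds named here.

Among the measured compounds shown here, compound 1 `O=C1c2c[n+]([O-])c3ccccc3c2C(=O)c2c1c1ccccc1n2Cc1cn(C[C@H](O)CO)nn1` gives 1310 nM in a functional assay on MDA-MB-231 cells (Homo sapiens) for cytotoxicity, read by MTT assay, with a stated time of 72 h (on this read-out lower numbers stand for stronger inhibition and higher numbers for weaker inhibition), the higher of the two numbers measured so far. Compound 2 `CN1CCN(CCCn2c3c(c4ccccc42)C(=O)c2c[n+]([O-])c4ccccc4c2C3=O)CC1` gives 390 nM, and the step of a 3.4-fold lower number from compound 1 to compound 2 (0.53 log units; beyond the scatter) concerned a different part of the molecule than the change now at hand. Compound 3 `O=C1c2c[n+]([O-])c3ccccc3c2C(=O)c2c1c1ccccc1n2Cc1cn([C@H]2C[C@H](O)[C@@H](CO)O2)nn1` differs from compound 1 by 4-hydroxy-5-(hydroxymethyl)oxolan-2-yl in place of 2,3-dihydroxypropyl on an aromatic nitrogen. For the measured compounds named here, no measured step touches this part of the molecule, so nothing measured bears directly on it. For compound 3 the expected step is a 1.0-fold lower number from compound 1 to compound 3 (0.00 log units; within the scatter), that is none beyond the scatter. Compound 3 is therefore estimated at 1300 nM, with a range from 500 nM to 3500 nM.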

Compound 3, half-maximal inhibitory concentration: 580 nM
Compound 3: the middle estimate sits 2.2-fold (0.35 log units) above what was measured; low and high end bracket the measured number.
By their numbers in this assay, from the lowest: compounds 2 and 3 (each within the scatter of the next); then compound 1.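

In this assay, putting 4-hydroxy-5-(hydroxymethyl)oxolan-2-yl in place of 2,3-dihydroxypropyl on the aromatic nitrogen gives a 2.3-fold lower number from compound 1 to compound 3 (0.35 log units; beyond the scatter). This shows that the group on this nitrogen, which the earlier step did not touch, can move the number beyond the scatter, even though both groups carry 2 hydrogen-bond donors. No measurement in hand accounts for this step. The compounds shown do not separate the contributions of the ring, the added oxygen and the stereocentres. As far as these compounds go, how an amine or a carboxylic acid on this nitrogen would read also remains open.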